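Swapping the amide arm for a carbamoyl arm

This account rests on a few compounds, and the source may have more. Where it says the series, first, only, none or still open, it means among the compounds named here.

Measured compounds:
Compound 1, `COc1cc(-c2nn(-c3cccc(NC(=O)c4cccc(C(F)(F)F)c4)c3)cc2-c2ccncc2)ccc1Cl`: 1020 nM
Compound 2, `O=C(Nc1cccc(-n2cc(-c3ccncc3)c(-c3ccc(Cl)c(O)c3)n2)c1)Nc1cc(C(F)(F)F)cc(C(F)(F)F)c1`: 620 nM
Compound 3, `O=C(Nc1cccc(-n2cc(-c3ccncc3)c(-c3ccc(Cl)c(O)c3)n2)c1)Nc1ccc(Cl)c(C(F)(F)F)c1`: 740 nM

These three compounds were tested in a functional assay on SF-295 cells (Homo sapiens) for inhibition, read by sulforhodamine B assay, with a stated time of 48 h; on this read-out higher numbers stand for weaker inhibition and lower numbers for stronger inhibition. Compound 1 gives the highest of the three numbers, yet its nearest neighbour is compound 3, whose number is lower by an amount within the scatter, and its furthest is compound 2, also lower but within the scatter. In other words, all three values sit in one band, and none can be called stronger or weaker than another.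

Compound 4 is `COc1cc(-c2nn(-c3cccc(NC(=O)Nc4ccc(Cl)c(Cl)c4)c3)cc2-c2ccncc2)ccc1Cl` and has not yet been measured. It differs from compound 1 in one place: (3,4-dichlorophenyl)amino in place of 3-(trifluoromethyl)phenyl on a carbonyl carbon. Cut one bond further out, the change reads as (3-(trifluoromethyl)phenyl)carbonyl giving way to (3,4-dichlorophenyl)carbamoyl, so the group sitting on the carbonyl carbon gains a hydrogen-bond donor.

Going by the values given here, no measured pair shows this exact change, so no step size is known. The narrow spread across compounds 1, 2 and 3 suggests that compound 4 is expected to land in the same band, with a 1.5-fold lower number from compound 1 to compound 4 (0.16 log units; within the scatter) expected to be small and most likely a slight drop in number, though perhaps nothing beyond the scatter. Compound 4 is therefore estimated at 700 nM, within 300 nM to 1600 nM.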

Compound 4, half-maximal inhibitory concentration: 690 nM
Estimate against measurement, compound 4: 1.0-fold (0.01 log units) above; measured number inside the range.
By their numbers in this assay, from the lowest: compounds 2, 4, 3 and 1 (each within the scatter of the next).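

In this assay, going by these compounds alone, putting (3,4-dichlorophenyl)amino in place of 3-(trifluoromethyl)phenyl on a carbonyl carbon gives a 1.5-fold lower number from compound 1 to compound 4 (0.17 log units; within the scatter) and is the first step in this set where the compounds differ in only one place. It shows that this arm can go from an amide-type link to a carbamoyl link, gaining 1 hydrogen-bond donor and a different set of ring substituents, with no change in the number that can be told from scatter. No accompanying measurement offers an explanation for this result.

This single step changes the link and the ring substituents together, so it cannot show whether either change alone would have an effect, or whether the two effects cancel out. As far as these compounds go, it also remains open whether a more drastic replacement on the same carbonyl carbon, such as a morpholine, a longer alkyl chain or a phenyl ring carrying a carboxylic acid, would move the number beyond the scatter.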